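Furan for Thiophene on the Side Chain of Compound 2

A few compounds are considered here, and "the series" means these few. Any claim that something is new, unique, unknown or untested is made for them only; others in the source may bear on it.

Compound 2 `CCn1c(=O)c2c(nc(Cc3cccs3)n2C)n(Cc2cccs2)c1=O` gives 95.5 nM in an assay on CHO cells for displacement of a labelled ligand from adenosine receptor A1 (Homo sapiens), read by scintillation counting; on this read-out higher numbers stand for weaker inhibition and lower numbers for stronger inhibition. Going by the values given here, of the two compounds measured so far, compound 2 stands at the lower number; compound 1 `CCn1c(=O)c2[nH]c(Cc3ccco3)nc2n(Cc2cccs2)c1=O`, which differs from it in several places, gives 407 nM in this assay, a gap beyond the usual scatter. Compound 3 `CCn1c(=O)c2c(nc(Cc3ccco3)n2C)n(Cc2cccs2)c1=O` has not been measured. It differs from compound 2 in one place: furan-2-yl in place of thiophen-2-yl on a saturated chain carbon bound to an aromatic carbon. Among the compounds with values here, no pair of measured compounds shows this exchange on its own, so the size of the step cannot be read off a known case. Compound 1 and compound 2 carry furan and thiophene at another place and differ elsewhere too, so their values show only where each of them lands. Compound 3 is expected to give 160 nM, within 60 nM to 420 nM. The expected step from compound 2 to compound 3 is a 1.7-fold higher number from compound 2 to compound 3 (0.22 log units; within the scatter), a modest move toward a higher number, close to the scatter.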

Compound 3, inhibition constant: 100 nM
The estimate for compound 3 lay 1.6-fold (0.20 log units) above the measured number, within the range that was stated.
By their numbers in this assay, from the lowest: compounds 2 and 3 (each within the scatter of the next); then compound 1.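

In this assay furan-2-yl in place of thiophen-2-yl on a saturated chain carbon bound to an aromatic carbon can now be read on its own: the exchange gives a 1.0-fold higher number from compound 2 to compound 3 (0.02 log units; within the scatter), so at this place the two groups cannot be told apart with the rest of compound 2 held fixed. Compound 3 also forms a single-place pair with compound 1, and methyl in place of hydrogen on an aromatic nitrogen gives a 4.1-fold lower number from compound 1 to compound 3 (0.61 log units; beyond the scatter), a step that the furan-2-yl series shows free of any other difference. Nothing available explains either step.

The compounds shown leave open whether the furan-2-yl exchange would read the same in a compound with hydrogen on the aromatic nitrogen. They also leave open what a phenyl ring or an amine would give on the same saturated chain carbon.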